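Replacing 4-ethylphenyl with piperidin-1-yl in the series

The source may report more compounds than this note shows. Statements on the series, on what has been measured and on what is new or still open speak of the compounds shown alone.

Measured in a functional assay on BXPC-3 cells (Homo sapiens) for cytotoxicity, read by MTT assay, with a stated time of 72 h (on this read-out lower numbers stand for stronger inhibition and higher numbers for weaker inhibition), so far:
- compound 1 (`O=C1C(Nc2ccc(C3CCCCC3)cc2)=CC(=O)c2ncncc21`): 500 nM
- compound 2 (`CCc1ccc(-c2ccc(NC3=CC(=O)c4ncncc4C3=O)cc2)cc1`): 1600 nM

Compound 2 holds the higher of the two numbers at 1600 nM and so stands at the weak end of this small set. Compound 3 (`O=C1C(Nc2ccc(N3CCCCC3)cc2)=CC(=O)c2ncncc21`) differs from compound 2 by piperidin-1-yl in place of 4-ethylphenyl on an aromatic carbon and keeps the shared core, with piperidin-1-yl in place of 4-ethylphenyl on an aromatic carbon. Going by the values given here, one measured step bears on this change: a 3.2-fold higher number from compound 1 to compound 2 (0.51 log units; beyond the scatter) (modest, 4-ethylphenyl in place of cyclohexyl). Here 4-ethylphenyl leaves again and a six-membered non-aromatic ring returns, but no measured step covers piperidin-1-yl itself. Among the compounds with values here, a modest expected move toward lower numbers follows, no larger than that step. The expected change is a 2.3-fold lower number from compound 2 to compound 3 (0.36 log units; beyond the scatter) in this assay as an estimate only. For compound 3 the estimated value is 700 nM with an expected range from 250 nM to 2000 nM in this read-out.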

Compound 3, half-maximal inhibitory concentration: 2500 nM
The estimate for compound 3 lay 3.6-fold (0.55 log units) below the measured number, and the stated range ends below it.
By their numbers in this assay, from the lowest: compound 1; then compounds 2 and 3 (each within the scatter of the next).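

In this assay, piperidin-1-yl in place of 4-ethylphenyl, para to a large group, gives a 1.6-fold higher number from compound 2 to compound 3 (0.19 log units; within the scatter), so this read-out does not separate the two groups at this position, although one is a six-membered aromatic ring of carbon only and the other a six-membered non-aromatic ring with 1 hetero atom. A six-membered non-aromatic ring alone does not preserve the value of compound 1, since piperidin-1-yl in place of cyclohexyl gives a 5.0-fold higher number from compound 1 to compound 3 (0.70 log units; beyond the scatter), the first sign that the identity of the non-aromatic ring matters here. No measurement at hand accounts for that difference.

On these data alone, it remains open whether the gap from compound 1 follows the ring nitrogen or the whole piperidine ring. Morpholin-4-yl, an open-chain dimethylamino group or a carbon-linked piperidin-4-yl at the same place would bear on that question.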